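From hydroxy to methoxy: compound 1 to compound 3

The source may report more compounds than this note shows. Statements on the series, on what has been measured and on what is new or still open speak of the compounds shown alone.

Among the measured compounds shown here, in a physicochemical assay, read by spectrophotometry, with a stated time of 15 min (on this read-out lower numbers stand for stronger inhibition and higher numbers for weaker inhibition), compound 1 `O=C(CCc1nc2ccccc2c(=O)[nH]1)N/N=C/c1ccc(O)c(O)c1` gives 105000000 nM and compound 2 `COc1cc(/C=N/NC(=O)CCCc2nc3ccccc3c(=O)[nH]2)cc(OC)c1OC` gives 85000000 nM and these two values lie within the scatter of each other, so compound 1 stands level with the only other measured compound. Compound 3 `COc1cc(/C=N/NC(=O)CCc2nc3ccccc3c(=O)[nH]2)ccc1O` differs from compound 1 by methyl in place of hydrogen on an oxygen on an aromatic ring with methyl in place of hydrogen on an oxygen on an aromatic ring. For the measured compounds named here, no measured pair shows this change. In this assay the expected result is a 1.1-fold lower number from compound 1 to compound 3 (0.02 log units; within the scatter) which stays within the scatter, with no direction favoured. For compound 3 the estimate is 100000000 nM with 45000000 nM to 220000000 nM as the expected range.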

Compound 3, half-maximal inhibitory concentration: 290000000 nM
Estimate against measurement, compound 3: 2.9-fold (0.46 log units) below; measured number above the stated range.
By their numbers in this assay, from the lowest: compounds 2 and 1 (each within the scatter of the next); then compound 3.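

In this assay, methyl in place of hydrogen on an oxygen on an aromatic ring gives a 2.8-fold higher number from compound 1 to compound 3 (0.44 log units; beyond the scatter), so hydroxy to methoxy on this ring weakens inhibition rather than leaving it level. Among the compounds shown here, this is the first step that changes one place only, and the comparison of compound 1 with compound 2 could not show it. Nothing at hand bears on the reason for the step.

Open, as far as these compounds go, is whether an amine or a carboxylic acid in place of this hydroxy keeps the number of compound 1. Also open, from the compounds shown here alone, is whether a longer chain than methyl on this oxygen moves the number further.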